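Thromboxane synthase series: carboxy to dimethylcarbamoyl step

The compounds below may be only part of what the source reports. "The series", "measured", "known", "first", "only" and "open" are said of these compounds alone.

Measured so far in a functional assay for inhibition of Thromboxane-A synthase (Homo sapiens); a higher number here means a weaker inhibitor, a lower number a stronger inhibitor:
compound 1 `COc1ccc(COCC(Cn2ccnc2)OCc2ccc(OC)cc2)cc1` gives 9900 nM;
compound 2 `CCCCOC(=O)c1ccc(COC(COCc2ccc(OC)cc2)Cn2ccnc2)cc1` gives 200 nM;
compound 3 `COc1ccc(COCC(Cn2ccnc2)OCc2ccc(C(=O)O)cc2)cc1` gives 6700 nM.

Compound 3 stands second highest of the three numbers. Its nearest neighbour is compound 1, the step of a 1.5-fold lower number from compound 1 to compound 3 (0.17 log units; within the scatter) lying within the scatter; its furthest is compound 2, the step of a 34-fold higher number from compound 2 to compound 3 (1.53 log units; beyond the scatter) being large and beyond the scatter. Compound 1 and compound 2 likewise differ by a 50-fold lower number from compound 1 to compound 2 (1.69 log units; beyond the scatter).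

Compound 4 `COc1ccc(COCC(Cn2ccnc2)OCc2ccc(C(=O)N(C)C)cc2)cc1` is not yet measured. It differs from compound 3 by dimethylamino in place of hydroxy on a carbonyl carbon. Among the compounds with values here, no measured step reaches a dimethylcarbamoyl group. Within the data shown here, the steps that bear on the carbonyl carbon are the replacement of butyl by hydrogen on the ester oxygen, a 34-fold higher number from compound 2 to compound 3 (1.53 log units; beyond the scatter), and the exchange of methoxy for butoxycarbonyl, a 50-fold lower number from compound 1 to compound 2 (1.69 log units; beyond the scatter). Among the measured compounds shown here, both were large, and both leave the single compound lacking a hydroxy on the carbonyl far below compound 1 and compound 3. For the measured compounds named here, compound 4 also lacks that hydroxy but carries no butyl chain, so in this assay a lower number than for compound 3 is expected, but a step smaller than the one from compound 2. The expected step is a 3.4-fold lower number from compound 3 to compound 4 (0.53 log units; beyond the scatter). Compound 4 is estimated at 2000 nM, within a range from 400 nM to 10000 nM.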

Compound 4, half-maximal inhibitory concentration: 1940 nM
Compound 4: middle estimate off by 1.0-fold (0.01 log units), on the high side, within the range that was stated.
By their numbers in this assay, from the lowest: compound 2; then compound 4; then compounds 3 and 1 (each within the scatter of the next).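

Notes on the substituent at this carbonyl carbon, read in this assay: dimethylamino in place of hydroxy gives a 3.5-fold lower number from compound 3 to compound 4 (0.54 log units; beyond the scatter), so this position responds to a change that keeps the carbonyl and alters only the group on it. Against the methoxy starting point, the dimethylcarbamoyl group gives a 5.1-fold lower number from compound 1 to compound 4 (0.71 log units; beyond the scatter), a step beyond the scatter that the carboxy group did not produce, which shows that a carbonyl substituent without a butyl chain can still lower the number. The butyl ester nevertheless keeps a clear margin, with dimethylamino in place of butoxy giving a 9.7-fold higher number from compound 2 to compound 4 (0.99 log units; beyond the scatter), and nothing available explains the order of these three carbonyl groups.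

As far as these compounds go, it remains open whether the margin held by compound 2 follows the butyl chain or the ester oxygen, a question that a methyl ester and an N-butyl amide would separate. Also open, from the compounds shown here alone, is how the number responds to the size of the amide substituents, from a primary amide to a diethylamino group.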